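The source may hold more compounds than are shown below. What is called first, only, known or untested is meant among the compounds shown, and "the series" means these compounds.

In a functional assay on HeLa cells (Homo sapiens) for cytotoxicity, read by sulforhodamine B assay, with a stated time of 48 h (on this read-out higher numbers stand for weaker inhibition and lower numbers for stronger inhibition), compound 3 (`C=CCOc1ccc(Br)cc1C(=O)c1cccnc1`) gives 96000 nM and holds the highest of the three numbers, the weakest inhibition so far. Compound 1 (`O=C(c1cccnc1)c1cc(F)ccc1O`) gives 27000 nM and compound 2 (`O=C(c1cccnc1)c1cc(Cl)ccc1O`) gives 24000 nM with a hydroxy group on the shared core. Compound 4 (`O=C(c1cccnc1)c1cc(Br)ccc1O`) differs from compound 3 by hydrogen in place of allyl on an oxygen on an aromatic ring. Among the measured compounds shown here, no measured step covers this allyloxy to hydroxy change directly. The nearest evidence is chloro in place of fluoro on an aromatic carbon, which gave a 1.1-fold lower number from compound 1 to compound 2 (0.05 log units; within the scatter) so compound 4, with bromo, is expected to sit close to that pair. The estimated step in this assay is a 3.8-fold lower number from compound 3 to compound 4 (0.58 log units; beyond the scatter) toward stronger inhibition. For compound 4 the expected value is 25000 nM with an estimated range from 12000 nM to 50000 nM as its limits.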

Compound 4, half-maximal inhibitory concentration: 29000 nM
Estimate against measurement, compound 4: 1.2-fold (0.06 log units) below; measured number inside the range.
By their numbers in this assay, from the lowest: compounds 2, 1 and 4 (each within the scatter of the next); then compound 3.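

Hydrogen in place of allyl on an oxygen on an aromatic ring strengthens inhibition modestly in this assay (a 3.3-fold lower number from compound 3 to compound 4 (0.52 log units; beyond the scatter)), which shows that this oxygen's substituent changes the result, at least with bromo on the shared core. With the hydroxy group present, bromo reads the same as chloro (a 1.2-fold higher number from compound 2 to compound 4 (0.08 log units; within the scatter)) and fluoro (a 1.1-fold higher number from compound 1 to compound 4 (0.03 log units; within the scatter)), so these three halogens cannot be told apart here. Nothing available explains the allyl step.

Going by these compounds, it remains open whether a methyl or a longer chain on this oxygen would read like allyl or like hydrogen. An amine in place of the hydroxy group is also untested among the compounds shown.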